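The compounds below may be only part of what the source reports. "The series", "measured", "known", "first", "only" and "open" are said of these compounds alone.

Compound 3 `CNC(=O)c1cc(Oc2ccc3nc(Nc4cccc(OC(F)(F)F)c4)ncc3c2)ccn1` is one of three compounds on a shared core that have been measured in a physicochemical assay for solubility, at pH 7; a lower number here means a less soluble compound, a higher number a more soluble compound. In this assay compound 3 gives < 1000 nM, which is a limit of the assay and not a read number. Compound 1 `CNC(=O)c1cc(Oc2ccc3nc(Nc4ccccc4)ncc3c2)ccn1` gives in this assay < 1000 nM, again only a limit. Compound 2 `CNC(=O)c1cc(Oc2ccc3nc(Nc4ccccc4Br)ncc3c2)ccn1` gives in this assay < 1000 nM, also a limit. So the limit of < 1000 nM in this assay, at which 3 of the 3 values shown sit, covers the whole set, and the steps a step that the two limits leave unreadable from compound 1 to compound 2, a step that the two limits leave unreadable from compound 1 to compound 3 and a step that the two limits leave unreadable from compound 2 to compound 3 cannot be sized.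

Compound 4 `CNC(=O)c1cc(Oc2ccc3nc(Nc4cccc(C(C)C)c4)ncc3c2)ccn1` differs from compound 3 by isopropyl in place of trifluoromethoxy on an aromatic carbon. For the measured compounds named here, none of the measured steps carries a readable size, so none of them sets a direction for this change. The step from compound 3 is expected to be a step that the limit leaves unreadable from compound 3 to compound 4, that is, no move that could be distinguished from the scatter. Compound 4 is therefore expected to give about 500 nM in this assay, with a range from 100 nM to 2500 nM, and most likely to be reported only as a limit once more.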

Compound 4, solubility: < 1000 nM
Compound 4 was reported as a limit (the forecaster's own chance of this, stated with the estimate: 75%); the middle value is on the limit's open side.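

In this assay compound 4 gives < 1000 nM, which is a limit of the assay. Its steps from compound 1, compound 2 and compound 3 therefore cannot be read, as the whole set sits at: the limit of < 1000 nM in this assay, at which 4 of the 4 values shown sit. The compounds shown leave open how large any step among these four compounds is, including that of isopropyl in place of trifluoromethoxy.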